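This account rests on a few compounds, and the source may have more. Where it says the series, first, only, none or still open, it means among the compounds named here.

In a functional assay on DU-145 cells (Homo sapiens) for cytotoxicity, read by MTT assay (a higher number here means a weaker inhibitor, a lower number a stronger inhibitor), compound 1 `COC(=O)C[C@H]1C[C@H](O)[C@@H](C)[C@@H](c2ccc(C)cc2)N1` gives 330000 nM and compound 2 `COC(=O)C[C@H]1C[C@H](O)[C@@H](C)[C@@H](c2ccc(OC)cc2)N1` gives 6500 nM. Compound 3 `COC(=O)C[C@H]1C[C@H](O)[C@@H](C)[C@@H](c2ccc(F)cc2)N1` is reported as "not active" (no number reported), without a number. Compound 2 therefore holds the lower of the two numbers available.

Compound 4 `COc1ccc([C@H]2N[C@@H](CCO)C[C@H](O)[C@H]2C)cc1` keeps the core of compound 2 but changes its side chain: hydroxymethyl in place of methoxycarbonyl on a saturated chain carbon bound to a saturated ring carbon. This places hydroxymethyl in place of methoxycarbonyl on a saturated chain carbon bound to a saturated ring carbon, so (methoxycarbonyl)methyl becomes 2-hydroxyethyl.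

Going by the values given here, no measured step covers this change. The only one, a 51-fold lower number from compound 1 to compound 2 (1.71 log units; beyond the scatter), is methoxy in place of methyl on an aromatic carbon, a different part of the molecule. It shows that one small edit can move the number a long way in this set, but it gives no direction for the new edit, so the range has to stay wide. Compound 2 at 6500 nM already sits lowest, so a higher number is the cautious expectation.

The expected change is a 3.8-fold higher number from compound 2 to compound 4 (0.59 log units; beyond the scatter), a moderate loss of strength. Compound 4 is estimated at 25000 nM, with an expected range from 4000 nM to 150000 nM.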

Compound 4, half-maximal inhibitory concentration: 14800 nM
Compound 4: the middle estimate sits 1.7-fold (0.23 log units) above what was measured, and the stated range covers the measured number.
By their numbers in this assay, from the lowest: compound 2; then compound 4; then compound 1.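

In this assay, replacing methoxycarbonyl with hydroxymethyl on a saturated chain carbon bound to a saturated ring carbon gives a 2.3-fold higher number from compound 2 to compound 4 (0.36 log units; beyond the scatter), a modest step beyond the usual scatter. This shows that the side chain also affects the number, but that compound 4 still gives a measurable value without the methoxycarbonyl group, and the change here is much smaller than a 51-fold lower number from compound 1 to compound 2 (1.71 log units; beyond the scatter), which was made on an aromatic carbon. No measured information explains this shift.

With only one replacement shown at this position, it remains open how a carboxylic acid, an amine or a longer chain would compare with hydroxymethyl. From the compounds shown here alone, it also remains open whether the same side-chain change would shift the number similarly on the core of compound 1, which carries methyl instead of methoxy.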